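Aryl variation at the carbonyl carbon of the shared core

A few compounds are considered here, and "the series" means these few. Any claim that something is new, unique, unknown or untested is made for them only; others in the source may bear on it.

Compound 1 `COc1cc(-c2cc(/C=C/C(=O)c3ccc(N)cc3)[nH]n2)cc(OC)c1OC` carries a 4-aminophenyl on the carbonyl carbon. In a functional assay on SN12C cells (Homo sapiens) for cytotoxicity, read by sulforhodamine B assay, with a stated time of 48 h, tested at 0.01 uM (on this read-out lower numbers stand for a stronger effect and higher numbers for a weaker effect at the one concentration tested), compound 1 gives 98%. Compound 2 `COc1cc(-c2cc(/C=C/C(=O)c3ccc(Cl)c(Cl)c3)[nH]n2)cc(OC)c1OC` has a 3,4-dichlorophenyl in that place, and in this assay compound 2 gives 98%. Among the compounds with values here, the one step measured so far, no change at the digits printed from compound 1 to compound 2 (within the scatter), shows that exchanging the aryl on the carbonyl carbon between these two groups leaves the read-out where it was. On the numbers shown, compound 2 stands level with compound 1.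

Compound 3 `COc1ccc(C(=O)/C=C/c2cc(-c3cc(OC)c(OC)c(OC)c3)n[nH]2)cc1OC` is the next member and has not yet been measured in this assay. Its change from compound 2 is 3,4-dimethoxyphenyl in place of 3,4-dichlorophenyl on a carbonyl carbon. Within the data shown here, the only step that bears on it is no change at the digits printed from compound 1 to compound 2 (within the scatter), an exchange of aryl at the same place that produced nothing beyond the scatter, and the series so far sits at a read-out that indicates little effect at this concentration. Compound 3 is therefore expected to show no step beyond the scatter, a number 1 percentage points lower from compound 2 to compound 3 (within the scatter). The estimate for compound 3 in this assay is 97%, within 86% to 104%.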

Compound 3, a percentage reported as activity, at one concentration (the size of the read-out at that concentration, not a potency): 99%
Compound 3: the middle estimate sits 2 percentage points below what was measured; low and high end bracket the measured number.
By their numbers in this assay, from the lowest: compounds 1, 2 and 3 (each within the scatter of the next).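

Read in this assay, the exchange of 3,4-dichlorophenyl for 3,4-dimethoxyphenyl on a carbonyl carbon gives a number 1 percentage points higher from compound 2 to compound 3 (within the scatter), and the exchange of 4-aminophenyl for the same group gives a number 1 percentage points higher from compound 1 to compound 3 (within the scatter). All three aryl groups at this place now stand within the scatter of one another, and this holds for an entering group with 2 hydrogen-bond acceptors and 10 heavy atoms in place of a leaving group with 0 hydrogen-bond acceptors and 8 heavy atoms. No other measurement accompanies these values, so the reason for the flat read-out remains unexplained.

The compounds shown leave open whether this place truly accepts any aryl group or whether the single low concentration simply lies where none of the three gives an effect, as a flat read-out at one concentration cannot separate these two cases. Also open, from the compounds shown here alone, is whether a group of another type on the carbonyl carbon, such as a carboxylic acid on the aryl ring or a straight butyl chain in place of the aryl ring, would move the read-out in this assay.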